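Trifluoromethyl on a Second Core: Expectation for Compound 4

The source may report more compounds than this note shows. Statements on the series, on what has been measured and on what is new or still open speak of the compounds shown alone.

Of the compounds shown here, three have been measured in a functional assay on HCT-116 cells (Homo sapiens) for cytotoxicity, read by MTT assay, with a stated time of 48 h, in the presence of a further agent that is not named here; on this read-out higher numbers stand for an effect only at larger amounts of compound and lower numbers for an effect already at smaller amounts. Compound 2 `Cn1ncc2c(-c3ccccc3)cc(NNC(=O)Nc3cc(Cl)nc(Cl)c3)nc21` gives 6240 nM. Compound 1 `Cn1nc(C(F)(F)F)c2c(-c3ccccc3)cc(NNC(=O)Nc3cc(Cl)nc(Cl)c3)nc21` differs from it by trifluoromethyl in place of hydrogen on an aromatic carbon and gives 18100 nM, a step of a 2.9-fold higher number from compound 2 to compound 1 (0.46 log units; beyond the scatter). Compound 3 `CCCc1cc(NNC(=O)Nc2cc(Cl)nc(Cl)c2)nc2c1cnn2C` has a different core, differing from compound 2 by propyl in place of phenyl on an aromatic carbon; in this assay compound 3 gives 76200 nM, a step of a 12-fold higher number from compound 2 to compound 3 (1.09 log units; beyond the scatter). Within the data shown here, compound 4 `CCCc1cc(NNC(=O)Nc2cc(Cl)nc(Cl)c2)nc2c1c(C(F)(F)F)nn2C` has not been measured; it differs from compound 3 by trifluoromethyl in place of hydrogen on an aromatic carbon, the same change at the same place as the one that led from compound 2 to compound 1. For compound 4 in this assay a step of a 2.9-fold higher number from compound 3 to compound 4 (0.46 log units; beyond the scatter) is expected. This expectation rests on a 2.9-fold higher number from compound 2 to compound 1 (0.46 log units; beyond the scatter), applied to compound 3 with its value of 76200 nM. The estimate for compound 4 is 220000 nM, with a likely range from 80000 nM to 600000 nM. Among the measured compounds shown here, only one earlier example of this change exists here, so the expectation is uncertain.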

Compound 4, half-maximal effective concentration: 38200 nM
Compound 4: the middle estimate sits 5.8-fold (0.76 log units) above what was measured; measured number below the stated range.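

With propyl on the core, trifluoromethyl in place of hydrogen gives a 2.0-fold lower number from compound 3 to compound 4 (0.30 log units; within the scatter) in this assay and so does not repeat the step seen on the phenyl compounds: the same change on two cores in this assay, a 2.9-fold higher number (0.46 log units; beyond the scatter) from compound 2 to compound 1 and a 2.0-fold lower number (0.30 log units; within the scatter) from compound 3 to compound 4, 5.8-fold (0.76 log units) apart, beyond the scatter of two such steps. Seen from the other side, propyl in place of phenyl gives a 2.1-fold higher number from compound 1 to compound 4 (0.32 log units; beyond the scatter) when trifluoromethyl is present, and this also differs from the step without it: the same change on two cores in this assay, a 12-fold higher number (1.09 log units; beyond the scatter) from compound 2 to compound 3 and a 2.1-fold higher number (0.32 log units; beyond the scatter) from compound 1 to compound 4, 5.8-fold (0.76 log units) apart, beyond the scatter of two such steps. The effect of each change therefore depends on the other group in these four compounds, but the data do not show why, or what either change would do on a third core.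

On these data alone, whether a longer chain or an amine in place of propyl would follow the phenyl or the propyl pattern remains open. So does the outcome of replacing trifluoromethyl with a single methyl group.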